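A Third Substituted Phenyl on a Shared Core

The source may hold more compounds than are shown below. What is called first, only, known or untested is meant among the compounds shown, and "the series" means these compounds.

Compound 1 `CC(=O)Oc1ccc2c(c1)C(C)=CC(C)(C)N2Cc1ccc(C#N)cc1` and compound 2 `CC(=O)Oc1ccc2c(c1)C(C)=CC(C)(C)N2Cc1ccc(Cl)c(Cl)c1` share one core and differ only in the substituted phenyl group it carries. Within the data shown here, in an ADME assay on L6 cells (Rattus norvegicus) for cytotoxicity, read by resazurin assay, with a stated time of 70 h (a higher number here means a weaker inhibitor, a lower number a stronger inhibitor), compound 1 gives 29000 nM and compound 2 gives 28000 nM, so compound 2 stands level with the only other measured compound. Among the measured compounds shown here, the one measured step, a 1.0-fold lower number from compound 1 to compound 2 (0.02 log units; within the scatter), came with the exchange of 4-cyanophenyl for 3,4-dichlorophenyl. Compound 3 `CC(=O)Oc1ccc2c(c1)C(C)=CC(C)(C)N2Cc1cccc(C)c1` brings a further exchange at that same place: 3-methylphenyl in place of 3,4-dichlorophenyl on a saturated chain carbon bound to a nitrogen on an aromatic ring in a ring. For the measured compounds named here, only that single step bears on this change, which makes it thin evidence, but it gives no ground for expecting a real shift in either direction in this assay. The expected size is no change at the digits printed from compound 2 to compound 3 (within the scatter), which would stay within the scatter. Compound 3 is estimated at 28000 nM, with an expected range of 13000 nM to 60000 nM.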

Compound 3, half-maximal inhibitory concentration: 28000 nM
Estimate against measurement, compound 3: no gap at the digits printed, and the stated range covers the measured number.
By their numbers in this assay, from the lowest: compounds 2, 3 and 1 (each within the scatter of the next).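

In this assay the exchange of 3,4-dichlorophenyl for 3-methylphenyl gives no change at the digits printed from compound 2 to compound 3 (within the scatter) and the exchange of 4-cyanophenyl for 3-methylphenyl gives a 1.0-fold lower number from compound 1 to compound 3 (0.02 log units; within the scatter) so both new steps stay within the scatter. Among these compounds, three substituted phenyl groups have now been compared at this place on the shared core, and they include a group with only carbon atoms, yet no pair among compounds 1, 2 and 3 can be told apart in this assay. No supporting measurement is available to explain why these numbers stay level.

All three compounds still carry a substituted phenyl group at this place. From the compounds shown here alone, whether the numbers would stay level with an amine or a carboxylic acid on that phenyl ring, or with a longer chain in place of the ring, remains open.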